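Swapping the Aryl Group on the Exocyclic Double Bond

A few compounds are considered here, and "the series" means these few. Any claim that something is new, unique, unknown or untested is made for them only; others in the source may bear on it.

Two compounds share a core and differ only in the aromatic group on a double-bonded chain carbon bound to a double-bonded ring carbon. Compound 1 `O=C1N=C(N2CCC[C@H]2C(=O)Nc2ccc3ncnc(Nc4cccc(Cl)c4)c3c2)S/C1=C/c1cccc(Cl)c1` carries a 3-chlorophenyl there, and in a functional assay on HepG2 cells (Homo sapiens) for antiproliferative activity, read by MTT assay (a lower number here means a stronger inhibitor, a higher number a weaker inhibitor), compound 1 gives 27600 nM. Compound 2 `Cc1cccc(/C=C2/SC(N3CCC[C@H]3C(=O)Nc3ccc4ncnc(Nc5cccc(Cl)c5)c4c3)=NC2=O)n1` carries a 6-methylpyridin-2-yl instead, and in this assay compound 2 gives 4500 nM. The step of a 6.1-fold lower number from compound 1 to compound 2 (0.79 log units; beyond the scatter) shows that this exchange helped. Going by the values given here, compound 2 therefore stands as the lower of the two numbers so far. Compound 3 `O=C1N=C(N2CCC[C@H]2C(=O)Nc2ccc3ncnc(Nc4cccc(Cl)c4)c3c2)S/C1=C/c1cccnc1` is the next variation: pyridin-3-yl in place of 6-methylpyridin-2-yl on a double-bonded chain carbon bound to a double-bonded ring carbon. Among the compounds with values here, the only step that bears on it, a 6.1-fold lower number from compound 1 to compound 2 (0.79 log units; beyond the scatter), shows that a nitrogen in this ring can matter, but no step shows what removing the methyl or moving the nitrogen does. The expected change from compound 2 to compound 3 in this assay is a 1.8-fold higher number from compound 2 to compound 3 (0.25 log units; within the scatter), a modest loss. The estimate for compound 3 in this assay is 8000 nM, with a range from 2500 nM to 25000 nM.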

Compound 3, half-maximal inhibitory concentration: 8500 nM
Compound 3: middle estimate off by 1.1-fold (0.03 log units), on the low side, within the range that was stated.
By their numbers in this assay, from the lowest: compounds 2 and 3 (each within the scatter of the next); then compound 1.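

In this assay the exchange of 6-methylpyridin-2-yl for pyridin-3-yl gives a 1.9-fold higher number from compound 2 to compound 3 (0.28 log units; within the scatter), so the two groups cannot be told apart here, even though they differ in the methyl and in where the ring nitrogen sits. Against the 3-chlorophenyl of compound 1, the new group gives a 3.2-fold lower number from compound 1 to compound 3 (0.51 log units; beyond the scatter), which means that two different pyridine rings on the double-bonded chain carbon now show the same direction of change. Nothing measured here explains that gain.

As far as these compounds go, whether the methyl and the place of the nitrogen each matter alone remains open, and a plain pyridin-2-yl would help to separate them. Also open, from the compounds shown here alone, is how a phenyl ring bearing an amine or a carboxylic acid would behave at this position.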